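Amide nitrogen substituent: compound 2 to compound 3

The compounds below may be only part of what the source reports. "The series", "measured", "known", "first", "only" and "open" are said of these compounds alone.

Measured in a functional assay on DU-145 cells (Homo sapiens) for antiproliferative activity, read by sulforhodamine B assay, with a stated time of 3 days (on this read-out higher numbers stand for weaker inhibition of growth and lower numbers for stronger inhibition of growth), as follows:
compound 1 (`COc1ccc(NC(=O)c2cccc(Nc3ncc(F)c(Nc4ccc(F)cc4)n3)c2)cc1`) gives > 10000 nM as a limit of the assay
compound 2 (`Cn1ccnc1NC(=O)c1cccc(Nc2ncc(F)c(Nc3ccc(F)cc3)n2)c1`) gives 15100 nM as a measured number

Within the data shown here, compound 2 holds the only actual number so far (15100 nM). Compound 1 is known only as a limit (> 10000 nM). Among the measured compounds shown here, the one measured step is a step that the limit leaves unreadable from compound 1 to compound 2 and it offers no size to carry forward.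

Compound 3 (`O=C(NCCO)c1cccc(Nc2ncc(F)c(Nc3ccc(F)cc3)n2)c1`) differs from compound 2 on the same amide-type nitrogen, and the change is 2-hydroxyethyl in place of 1-methyl-1H-imidazol-2-yl on an amide-type nitrogen in which a one-ring group gives way to a chain with no ring. For the measured compounds named here, no measured step involves 2-hydroxyethyl. The expectation therefore rests on compound 2 at 15100 nM and on the unreadable step alone, and no shift beyond the usual scatter is expected in this assay in either direction.

Compound 3 is estimated at 15000 nM with an expected range from 5000 nM to 40000 nM in this read-out. The expected step is a 1.0-fold lower number from compound 2 to compound 3 (0.00 log units; within the scatter) on this estimate.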

Compound 3, concentration for 50% growth inhibition: 13400 nM
Compound 3: the middle estimate sits 1.1-fold (0.05 log units) above what was measured; measured number inside the range.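

At the amide-type nitrogen, this assay now yields a first readable step, a 1.1-fold lower number from compound 2 to compound 3 (0.05 log units; within the scatter). The ring-free 2-hydroxyethyl and the one-ring 1-methyl-1H-imidazol-2-yl therefore cannot be told apart on this read-out, so within this pair, a five-membered aromatic ring on this nitrogen makes no readable difference. Compound 1, with 4-methoxyphenyl on the same nitrogen, gives > 10000 nM, which is a limit of the assay, and the steps from it to the other two compounds cannot be read: the limit of > 10000 nM in this assay, at which 1 of the 3 values shown sits.

The compounds shown leave open whether any group on this nitrogen can move the number beyond the scatter, for example a basic amine such as 2-aminoethyl, a carboxylic acid, or a longer chain ending in hydroxyl. They also leave open whether the lack of a readable difference between 1-methyl-1H-imidazol-2-yl and 2-hydroxyethyl would hold if the shared core were altered elsewhere, since all three compounds carry the same core.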